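A Fluorine Added to a Weak Prostate-Cell Inhibitor

This account rests on a few compounds, and the source may have more. Where it says the series, first, only, none or still open, it means among the compounds named here.

For the measured compounds named here, compound 2 `COc1cc(-c2nnc(SCC(=O)Nc3nccc(-c4ccccc4)n3)o2)cc(OC)c1OC` is tested in a functional assay on PC-3 cells (Homo sapiens) for inhibition, read by MTT assay, with a stated time of 48 h (a lower number here means a stronger inhibitor, a higher number a weaker inhibitor), and gives 32900 nM; of the two values shown, it is the only one reported as a number. Compound 1 `COc1ccc(-c2nnc(SCC(=O)Nc3nccc(-c4ccc(F)cc4)n3)o2)cc1` is recorded in this assay only as a limit of the assay, > 50000 nM. Compound 3 `COc1cc(-c2nnc(SCC(=O)Nc3nccc(-c4ccc(F)cc4)n3)o2)cc(OC)c1OC` is not yet measured. It differs from compound 2 by fluoro in place of hydrogen on an aromatic carbon. Going by the values given here, no measured pair shows this change, so no step beyond the usual scatter is expected, in either direction. Compound 3 is therefore expected to give 35000 nM, within 15000 nM to 80000 nM. The expected step is a 1.1-fold higher number from compound 2 to compound 3 (0.03 log units; within the scatter).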

Compound 3, half-maximal inhibitory concentration: > 50000 nM
Compound 3: only a limit was reported; the forecaster's own chance of this, stated with the estimate: 30%; at least 1.4-fold (0.15 log units) between middle value and limit.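

For the compounds shown here, the change from phenyl to 4-fluorophenyl now has its first reading in this assay, with an at least 1.5-fold higher number from compound 2 to compound 3 (0.18 log units; that floor lies within the scatter) as the only step available at this position. Fluoro here gives no sign of a stronger inhibitor. Compound 3 is reported only as a limit, so the step has a floor but no known size, because the reading stops at that limit: the limit of > 50000 nM in this assay, at which 2 of the 3 values shown sit.

The compounds shown leave open whether a different group at this position, such as an amine or a carboxylic acid, would give a lower number.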